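The source may report more compounds than this note shows. Statements on the series, on what has been measured and on what is new or still open speak of the compounds shown alone.

Of the compounds shown here, three have been tested so far in an assay on CHO cells for displacement of a labelled ligand from adenosine receptor A1 (Homo sapiens), read by scintillation counting, with a stated time of 60 min, tested at 10 uM; on this read-out higher numbers stand for more inhibition at the one concentration tested (going by the name of the read-out) and lower numbers for less inhibition. Compound 1, `O=C(NC1CCCC1)c1cc2ccccc2oc1=O`, gives 16% in this assay. Compound 2, `N=c1oc2ccc(Br)cc2cc1C(=O)NCCO`, gives 26%. Compound 3, `COc1ccc(-n2cnc(C#N)c2NC(=O)c2cc3cccc(OC)c3oc2=N)cc1`, gives 37%. Within the data shown here, the number for compound 2 lies within the usual scatter of the number for compound 1, so nothing can be said about which of these two gives the higher inhibition in this assay; compound 3 gives a number beyond the scatter above compound 2, and it is the one compound here that stands clearly apart from compound 2.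

Compound 4, `N=c1oc2ccc(Br)cc2cc1C(=O)NCCCO`, has not yet been measured. It differs from compound 2 in one place: hydroxymethyl in place of hydroxy on a saturated chain carbon, two bonds along the chain from an amide-type nitrogen. The chain that carries the hydroxy group grows by one carbon, and everything else in the structure is kept. Among the measured compounds shown here, no pair of measured compounds here differs in just this way, so no measured step guides the expectation. An unchanged core with a chain lengthened by one carbon is expected to move this assay little, if at all, with no clear direction beyond the scatter. For compound 4 the expected step from compound 2 is therefore a number 2 percentage points higher from compound 2 to compound 4 (within the scatter). Compound 4 is estimated to give 28%, expected to fall between 12% and 44%.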

Compound 4, a percentage reported as inhibition, at one concentration (the size of the read-out at that concentration, not a potency): 32%
Estimate against measurement, compound 4: 4 percentage points below, within the range that was stated.
By their numbers in this assay, from the lowest: compounds 1, 2, 4 and 3 (each within the scatter of the next, the first and the last beyond it).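

In this assay, the chain carrying the hydroxy group grows by one carbon, from 2-hydroxyethyl to 3-hydroxypropyl, and this gives a number 6 percentage points higher from compound 2 to compound 4 (within the scatter). Among these compounds, this is the first measured step in which only one place changes, and it shows that adding this carbon on the amide nitrogen does not shift the result beyond the normal variation between repeated measurements. The step therefore gives no direction for this change, and no other measurement here helps to interpret it.

From the compounds shown here alone, it remains open whether a longer chain, such as 4-hydroxybutyl, would produce a clear change at this position. Going by these compounds, it is also open whether an amine or a carboxylic acid at the end of the chain, in place of the hydroxy group, would move the result beyond that variation.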